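A 4-Methoxyphenyl Group Enters Where Two Compounds Sit at the Limit

This account rests on a few compounds, and the source may have more. Where it says the series, first, only, none or still open, it means among the compounds named here.

Compound 1 `O=C(NC1CCCCCC1)c1c(-c2ccccc2)c(-c2ccccc2)cn(Cc2ccc(F)cc2)c1=O`: in an assay on HEK293 cells for inhibition of Monoacylglycerol lipase ABHD6 (Homo sapiens), with stated times of 30 min and 5 min (a lower number here means a stronger inhibitor, a higher number a weaker inhibitor), compound 1 gives only a limit, > 10000 nM.
Compound 2 `O=C(NC1CCCCCC1)c1c(-c2ccccc2)ccn(Cc2ccc(F)cc2)c1=O`: in this assay compound 2 likewise gives only a limit, > 10000 nM.

Going by the values given here, compound 2 therefore stands nowhere definite on these numbers: its value in this assay is a limit of the assay rather than a measured strength, and the one other value shown is a limit too. Among the compounds with values here, the only measured step, a step that the two limits leave unreadable from compound 1 to compound 2, cannot be read in either direction, since (the limit of > 10000 nM in this assay, at which 2 of the 2 values shown sit). Compound 3 `COc1ccc(-c2cn(Cc3ccc(F)cc3)c(=O)c(C(=O)NC3CCCCCC3)c2-c2ccccc2)cc1` differs from compound 2 by 4-methoxyphenyl in place of hydrogen on an aromatic carbon. Going by these compounds, the step from compound 1 to compound 2 bears on it only loosely: it replaces a phenyl group on an aromatic carbon by hydrogen, the reverse kind of change to the one now made, and its size is unknown. Within the data shown here, no measured step shows how large an effect such a change has here. In this assay the expected step that the limit leaves unreadable from compound 2 to compound 3 is accordingly none beyond the scatter, and compound 3 will most likely again be reported only as a limit. The estimate for compound 3 is 15000 nM, ranging from 3000 nM to 60000 nM.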

Compound 3, half-maximal inhibitory concentration: > 10000 nM
Compound 3: a limit, no number; the forecaster's own chance of this, stated with the estimate: 75%; the middle value lies beyond the limit too.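

Compound 3 also gives only a limit in this assay (> 10000 nM). Going by these compounds alone, no step among compound 1, compound 2 and compound 3 can be read, in size or in direction: (the limit of > 10000 nM in this assay, at which 3 of the 3 values shown sit). The compounds shown leave open how strongly any of the three inhibits this enzyme, and whether adding the 4-methoxyphenyl group changes that strength at all.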